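The source may report more compounds than this note shows. Statements on the series, on what has been measured and on what is new or still open speak of the compounds shown alone.

Measured compounds in this series:

compound 1 `CC(O)c1cn(Cc2cc(=O)oc3cc(O)ccc23)nn1` — > 100000 nM
compound 2 `O=c1cc(Cn2cc(CCCO)nn2)c2ccc(O)cc2o1` — > 100000 nM
compound 3 `O=c1cc(Cn2cc(-c3cc(F)cc(F)c3)nn2)c2ccc(O)cc2o1` — 66700 nM

In a functional assay on SW-620 cells (Homo sapiens) for inhibition, read by MTT assay, with a stated time of 72 h (on this read-out higher numbers stand for weaker inhibition and lower numbers for stronger inhibition), compound 1 gives > 100000 nM, which is a limit of the assay and not a number. Compound 2 likewise gives only a limit, > 100000 nM. Compound 3 gives 66700 nM. Compound 2 therefore stands at the limit of > 100000 nM in this assay, at which 2 of the 3 values shown sit, and no number beyond that limit is known for it.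

Compound 4 `O=c1cc(Cn2cc(CSC(=S)N3CCOCC3)nn2)c2ccc(O)cc2o1` differs from compound 2 by a group of 9 heavy atoms (5 carbon, 1 nitrogen, 1 oxygen, 2 sulfur; one six-membered non-aromatic ring with 2 hetero atoms) in place of a group of 3 heavy atoms (2 carbon, 1 oxygen; no ring), on a saturated chain carbon bound to an aromatic carbon. The measured steps that touch this position all swap the substituent on the triazole carbon. The step that the two limits leave unreadable from compound 1 to compound 2 cannot be read. Going by the values given here, the steps of an at least 1.4-fold lower number from compound 1 to compound 3 (0.17 log units; that floor lies within the scatter) and an at least 1.4-fold lower number from compound 2 to compound 3 (0.17 log units; that floor lies within the scatter) only set a floor that lies within the scatter, so the one readable change at this position, exchanging a hydroxyalkyl tail for a 3,5-difluorophenyl, gave at most a modest lowering of the number.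

For compound 4, which again replaces the hydroxyalkyl tail with a larger group without a donor, a similar small lowering at best is expected, an at least 1.4-fold lower number from compound 2 to compound 4 (0.15 log units; that floor lies within the scatter). Compound 4 is estimated at 70000 nM, between 20000 nM and 200000 nM, with a real chance that only a limit is reported.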

Compound 4, half-maximal inhibitory concentration: >= 100000 nM
Compound 4: no number, only a limit; the forecaster's own chance of this, stated with the estimate: 45%; middle value at least 1.4-fold (0.15 log units) away from the limit.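

Going by these compounds alone, compound 4 gives >= 100000 nM in this assay, which is a limit and not a number; compound 2 also stands only at a limit, so no step between these two compounds can be read. The compounds shown leave open where the true values of compound 2 and compound 4 lie, and whether this exchange changes the read-out at all.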